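The compounds below may be only part of what the source reports. "The series", "measured", "known", "first", "only" and "open" are said of these compounds alone.

The series shares one core. Compound 1 `Cc1noc(C)c1-c1cnc(N)c(Oc2ccc(C(=O)Nc3ccccc3)cc2)n1` gives 5740 nM in a functional assay on LoVo cells (Homo sapiens) for inhibition, read by MTT assay, with a stated time of 72 h (on this read-out lower numbers stand for stronger inhibition and higher numbers for weaker inhibition), and compound 2 `Cc1noc(C)c1-c1cnc(N)c(Oc2ccc(C(=O)Nc3ccc(Cl)cn3)cc2)n1` gives 9180 nM in this assay. Among the measured compounds shown here, the single measured step, a 1.6-fold higher number from compound 1 to compound 2 (0.20 log units; within the scatter), leaves these two numbers within the scatter of each other, so compound 2 is not set apart from compound 1 by anything the data show. Compound 3 `Cc1noc(C)c1-c1cnc(N)c(Oc2ccc(C(=O)Nc3cc(Cl)ccn3)cc2)n1` is the next member; the change 4-chloropyridin-2-yl in place of 5-chloropyridin-2-yl on an amide-type nitrogen keeps the same atoms and only rearranges where the chlorine sits on the ring. For the measured compounds named here, no measured step tests such a rearrangement; the one step that touched this amide-type nitrogen, a 1.6-fold higher number from compound 1 to compound 2 (0.20 log units; within the scatter), stayed within the scatter, and the account therefore expects for compound 3 in this assay a step of a 1.0-fold lower number from compound 2 to compound 3 (0.01 log units; within the scatter), meaning no change beyond the scatter. Compound 3 is accordingly estimated at 9000 nM, with a range from 4000 nM to 20000 nM.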

Compound 3, half-maximal inhibitory concentration: > 100000 nM
Compound 3: no number, only a limit; the forecaster's own chance of this, stated with the estimate: 5%; middle value at least 11-fold (1.04 log units) from the limit.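

For compound 3 the reading in this assay is a limit of the assay and not a number: the limit of > 100000 nM in this assay, at which 1 of the 3 values shown sits. Even as a limit it marks a large change on the amide-type nitrogen, where moving the chlorine without changing the atoms gives an at least 10-fold higher number from compound 2 to compound 3 (1.03 log units; beyond the scatter), whereas the earlier exchange at this nitrogen stayed within the scatter. The comparison with the phenyl group gives an at least 17-fold higher number from compound 1 to compound 3 (1.24 log units; beyond the scatter), so at this place the ring carrying chlorine at the 4-position is set apart from both earlier groups, which the first two compounds alone could not show.

The compounds shown leave open whether this weakening is tied to chlorine itself or to any group at that ring position. A plain pyridin-2-yl, 4-methylpyridin-2-yl or 4-methoxypyridin-2-yl on the same nitrogen would separate these readings.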